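The source may hold more compounds than are shown below. What is called first, only, known or untested is meant among the compounds shown, and "the series" means these compounds.

Measured in an assay on CHO cells for inhibition of metabotropic glutamate receptor 1 (Rattus norvegicus); on this read-out higher numbers stand for weaker inhibition and lower numbers for stronger inhibition: compound 1 `Cc1c(C(=O)OC(C)(C)C)c[nH]c1C(=O)OC(C)(C)C` gives 100 nM. Compound 2 `Cc1c(C(=O)OC(C)(C)C)c[nH]c1C(=O)OCC1CC1` gives 48 nM. Compound 3 `CCN1CCC(OC(=O)c2[nH]cc(C(=O)OC(C)C(C)(C)C)c2C)C1` gives 260 nM.

Compound 2 holds the lowest number of the three. Within the data shown here, its nearest neighbour is compound 1, separated by a 2.1-fold lower number from compound 1 to compound 2 (0.32 log units; beyond the scatter); compound 3 sits further off at a clearly higher number than compound 2, and no single-point step connects those two.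

Compound 4 `CCCOC(=O)c1[nH]cc(C(=O)OC(C)(C)C)c1C` has not yet been measured. It differs from compound 2 by ethyl in place of cyclopropyl on a saturated chain carbon bound to an oxygen next to a carbonyl group. Among the measured compounds shown here, only one measured step touches this oxygen: a 2.1-fold lower number from compound 1 to compound 2 (0.32 log units; beyond the scatter), a modest shift obtained by exchanging the whole ester group there. For the measured compounds named here, the present change is a smaller exchange than that one, and no measured pair sets propyl against cyclopropylmethyl, so there is no direct precedent for it. The expectation is therefore no step beyond the scatter in this assay, with at most a slight drift toward a higher number. The estimated step of a 1.5-fold higher number from compound 2 to compound 4 (0.16 log units; within the scatter) expresses this. Compound 4 is expected to give about 70 nM, within a range of 30 nM to 170 nM.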

Compound 4, half-maximal inhibitory concentration: 75 nM
Compound 4: middle estimate off by 1.1-fold (0.03 log units), on the low side; the measured number falls inside the stated range.
By their numbers in this assay, from the lowest: compounds 2, 4 and 1 (each within the scatter of the next, the first and the last beyond it); then compound 3.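

In this assay, replacing cyclopropyl with ethyl on the saturated chain carbon bound to the oxygen, which amounts to cyclopropylmethyl to propyl, gives a 1.6-fold higher number from compound 2 to compound 4 (0.19 log units; within the scatter) and so adds a step at this place that stays inside the scatter. The three-membered ring is therefore not needed here to remain within the scatter of compound 2, at least against this open chain. Among these compounds, the second step, a 1.3-fold lower number from compound 1 to compound 4 (0.12 log units; within the scatter), is also inside the scatter, so compound 4 cannot be told apart from either end of a 2.1-fold lower number from compound 1 to compound 2 (0.32 log units; beyond the scatter) and the only step beyond the scatter at this oxygen now has an intermediate that is within the scatter of both compounds. No supporting data are available to explain these steps.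

Among the compounds shown here, still open is how a carboxylic acid or a longer chain such as hexyl at this oxygen would read in this assay, as all the single-place steps so far are confined to small carbon-only groups. Compound 3 differs from the others in more than one place, so the contribution of each of its two ester groups stays unresolved.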